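The source may hold more compounds than are shown below. What is called first, only, known or untested is meant among the compounds shown, and "the series" means these compounds.

Measured so far:
Compound 1 `C/C=C/C(=O)Nc1c(C(O)(C(F)(F)F)C(F)(F)F)ccc2ccccc12` gives 72 nM in an assay on LtK cells with ATP-sensitive inward rectifier potassium channel 11 (Homo sapiens) as the target; a higher number here means that more compound is needed for the effect, a lower number that less compound is needed.
Compound 2 `O=C(Nc1c(C(O)(C(F)(F)F)C(F)(F)F)ccc2ccccc12)c1cccc(Cl)c1` gives 98 nM in this assay.

Both compounds share the same core and differ only in the group on the carbonyl carbon, 3-chlorophenyl in compound 2 in place of prop-1-en-1-yl in compound 1. That single step, a 1.4-fold higher number from compound 1 to compound 2 (0.13 log units; within the scatter), is the only one available. Compound 2 stands as the higher of the two numbers, but since the gap to compound 1 lies within the scatter, the two compounds are best regarded as equal in this assay.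

Compound 3 `COc1ccc(C(=O)Nc2c(C(O)(C(F)(F)F)C(F)(F)F)ccc3ccccc23)cc1` is the next compound, differing from compound 2 in one place: 4-methoxyphenyl in place of 3-chlorophenyl on a carbonyl carbon. Among the compounds with values here, no measured pair changes the substituent on the phenyl ring itself, so the step from compound 2 bears on compound 3 only loosely, by showing that the one change tried so far left the number within the scatter. On that basis, compound 3 is expected to show a 1.2-fold higher number from compound 2 to compound 3 (0.09 log units; within the scatter), no step beyond the scatter. Compound 3 is therefore estimated at 120 nM, with a likely range from 40 nM to 400 nM.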

Compound 3, half-maximal effective concentration: 417 nM
For compound 3 the middle estimate is 3.5-fold (0.54 log units) below the measured one; measured number above the stated range.
By their numbers in this assay, from the lowest: compounds 1 and 2 (each within the scatter of the next); then compound 3.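

The group on the carbonyl carbon does matter in this assay: replacing 3-chlorophenyl with 4-methoxyphenyl gives a 4.3-fold higher number from compound 2 to compound 3 (0.63 log units; beyond the scatter), and replacing prop-1-en-1-yl with 4-methoxyphenyl gives a 5.8-fold higher number from compound 1 to compound 3 (0.76 log units; beyond the scatter), so more of compound 3 is needed for the effect. Having a six-membered aromatic ring at this position does not by itself fix the number, as compound 2 and compound 3 both carry one and still differ beyond the scatter, while compound 1 carries none and stays within the scatter of compound 2. No measurement available here explains why the number rises with 4-methoxyphenyl.

As far as these compounds go, the step from compound 2 to compound 3 changes both the substituent on the phenyl ring and the number in its name, so it remains open whether the methoxy group or its place on the ring goes with the higher number, a question that 3-methoxyphenyl or 4-chlorophenyl at this position would help to settle. Also open, from the compounds shown here alone, is how the number responds to quite different groups here, such as a longer saturated chain or a phenyl ring carrying an amine or a carboxylic acid.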